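Shortening the ester chain: from compound 2 to compound 3

The source may report more compounds than this note shows. Statements on the series, on what has been measured and on what is new or still open speak of the compounds shown alone.

Two members of the shared core have been measured. Compound 1 `CCCC(=O)C1=C(C)NC(=O)NC1c1ccco1` gives 1% in an assay on membranes from CHO cells for displacement of a labelled ligand from adenosine receptor A1 (Homo sapiens), read by scintillation counting, with a stated time of 60 min, tested at 1 uM; a higher number here means more inhibition at the concentration tested (going by the name of the read-out), a lower number less inhibition. Compound 2 `CCC(CC)OC(=O)C1=C(C)NC(=O)NC1c1ccco1` gives 2% in this assay. Among the measured compounds shown here, the only step between them, a number 1 percentage points higher from compound 1 to compound 2 (within the scatter), exchanges (pentan-3-yl)oxy for propyl on a carbonyl carbon and lies within the scatter. Compound 2 therefore shows the higher of the two numbers, but its nearest neighbour, compound 1, is within the scatter, so the two cannot be told apart.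

Compound 3 `CCC(C)OC(=O)C1=C(C)NC(=O)NC1c1ccco1` differs from compound 2 by hydrogen in place of methyl on a saturated chain carbon, two bonds along the chain from an oxygen next to a carbonyl group. For the measured compounds named here, no measured step alters the same saturated chain carbon; the one step on record, a number 1 percentage points higher from compound 1 to compound 2 (within the scatter), touches the same carbonyl carbon from the other side and shows that a larger change to this group left the number within the scatter. Because of a number 1 percentage points higher from compound 1 to compound 2 (within the scatter), no step beyond the scatter is expected in this assay, in either direction. Compound 3 is estimated at 2%, with a range from -6% to 10%, which corresponds to an expected step of no change at the digits printed from compound 2 to compound 3 (within the scatter).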

Compound 3, a percentage reported as inhibition, at one concentration (the size of the read-out at that concentration, not a potency): 6%
For compound 3 the middle estimate is 4 percentage points below the measured one; the measured number falls inside the stated range.
By their numbers in this assay, from the lowest: compounds 1, 2 and 3 (each within the scatter of the next).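

In this assay, among the compounds shown here, the first measured change at this saturated chain carbon, hydrogen in place of methyl, gives a number 4 percentage points higher from compound 2 to compound 3 (within the scatter), so going from (pentan-3-yl)oxy to sec-butoxy cannot be told apart from no change. On the same carbonyl carbon, sec-butoxy in place of propyl gives a number 5 percentage points higher from compound 1 to compound 3 (within the scatter), so compounds 1, 2 and 3 remain indistinguishable in this read-out and the three groups on this carbonyl carbon show no order among them. No measurement available here bears on this result.

From the compounds shown here alone, whether a longer chain on the oxygen, or an amine or a carboxylic acid on this saturated chain carbon, would give a step beyond the scatter remains open. The compounds shown also leave open whether a change elsewhere on the shared core would give a higher number in this assay than any change at this carbonyl carbon.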